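Ring Swap at the Aromatic Carbon of Compound 3

The source may report more compounds than this note shows. Statements on the series, on what has been measured and on what is new or still open speak of the compounds shown alone.

Of the compounds shown here, three sharing one core have been measured in an assay on HEK293 cells for inhibition of acid ceramidase (Homo sapiens), read by fluorescence, with stated times of 10 min and 3 h; a higher number here means a weaker inhibitor, a lower number a stronger inhibitor. Compound 1 `O=C(NCCCCc1ccccc1)n1c(=O)oc2cc(C3CCOCC3)ccc21` gives 68 nM, compound 2 `CC(=O)N1CCC(c2ccc3c(c2)oc(=O)n3C(=O)NCCCCc2ccccc2)CC1` gives 64 nM, and compound 3 `CN1CCC(c2ccc3c(c2)oc(=O)n3C(=O)NCCCCc2ccccc2)CC1=O` gives 105 nM, the largest of the three numbers, though a 1.5-fold higher number from compound 1 to compound 3 (0.19 log units; within the scatter) and a 1.6-fold higher number from compound 2 to compound 3 (0.22 log units; within the scatter) both lie within the scatter, as does a 1.1-fold lower number from compound 1 to compound 2 (0.03 log units; within the scatter). Compound 4 `O=C(NCCCCc1ccccc1)n1c(=O)oc2cc(C3CCCCC3)ccc21` has not yet been measured. It differs from compound 3 in one place: cyclohexyl in place of 1-methyl-2-oxopiperidin-4-yl on an aromatic carbon. Within the data shown here, the steps that bear on this change are the two that also exchange the saturated ring on that aromatic carbon, from compound 1 to compound 3 and from compound 2 to compound 3, and neither moved this assay beyond the scatter. Since the three measured rings, with their differing hetero atom content, all gave similar numbers, the step to a ring of carbon only is expected to be small: a 1.3-fold lower number from compound 3 to compound 4 (0.12 log units; within the scatter). Compound 4 is therefore estimated to give 80 nM, within a range of 30 nM to 250 nM.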

Compound 4, half-maximal inhibitory concentration: 89 nM
Compound 4: middle estimate off by 1.1-fold (0.05 log units), on the low side, within the range that was stated.
By their numbers in this assay, from the lowest: compounds 2, 1, 4 and 3 (each within the scatter of the next).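

In this assay, compound 4 brings the first ring of carbon only to this aromatic carbon, and it stays within the scatter of all three rings that carry a hetero atom: a 1.2-fold lower number from compound 3 to compound 4 (0.07 log units; within the scatter) and a 1.4-fold higher number from compound 2 to compound 4 (0.14 log units; within the scatter) and a 1.3-fold higher number from compound 1 to compound 4 (0.12 log units; within the scatter). The earlier compounds showed only exchanges among rings with a hetero atom, whereas these steps show that, among the four six-membered non-aromatic rings shown, the ring hetero atom and hydrogen-bond acceptor can both be absent without a step beyond the scatter. Nothing offered here explains this tolerance.

Every group shown at this position is a six-membered non-aromatic ring, so a phenyl ring, a smaller cyclopropyl ring or an open butyl chain remains untested here. Also open, as far as these compounds go, is whether a ring bearing a free amine or a carboxylic acid would stay within the scatter.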